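The source may report more compounds than this note shows. Statements on the series, on what has been measured and on what is new or still open speak of the compounds shown alone.

The measured compounds:
compound 1, `CC/N=C(\S)OC[C@H]1OC(n2cnc3c(NC4CCOC4)ncnc32)[C@H](O)[C@@H]1O`, 33 nM
compound 2, `CCC/N=C(\S)OC[C@H]1OC(n2cnc3c(NC4CCOC4)ncnc32)[C@H](O)[C@@H]1O`, 50 nM
compound 3, `O=C(NC1CC1)OC[C@H]1OC(n2cnc3c(NC4CCOC4)ncnc32)[C@H](O)[C@@H]1O`, 209 nM

These three share one core and differ only in the group attached through an oxygen on a saturated carbon. In an assay on DDT1 cells (Cricetulus griseus) for binding affinity to adenosine receptor A1 (Homo sapiens), read by radioligand binding (a lower number here means a stronger inhibitor, a higher number a weaker inhibitor), compound 2 stands second highest of the three numbers. Its nearest neighbour is compound 1, and the step of a 1.5-fold higher number from compound 1 to compound 2 (0.18 log units; within the scatter) is small, so the two cannot be told apart. The step of a 4.2-fold higher number from compound 2 to compound 3 (0.62 log units; beyond the scatter) sets compound 3 further off.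

Compound 4, `C=CC/N=C(\S)OC[C@H]1OC(n2cnc3c(NC4CCOC4)ncnc32)[C@H](O)[C@@H]1O`, has not yet been measured. It differs from compound 2 by vinyl in place of ethyl on a saturated chain carbon bound to a double-bonded nitrogen; cut one bond further out, the same difference reads propyl to allyl. The chain keeps its length, and one double bond outside aromatic rings is added.

The step that bears most on this is a 1.5-fold higher number from compound 1 to compound 2 (0.18 log units; within the scatter), a lengthening of the same chain that changed the number little. The steps of a 6.3-fold higher number from compound 1 to compound 3 (0.80 log units; beyond the scatter) and a 4.2-fold higher number from compound 2 to compound 3 (0.62 log units; beyond the scatter) concern a different group on the same oxygen and are of modest size. Nothing measured here touches a double bond in this chain. The step of a 1.1-fold lower number from compound 2 to compound 4 (0.05 log units; within the scatter) is therefore expected to stay within the scatter, with no clear direction. Compound 4 is estimated at 45 nM, with a range from 20 nM to 100 nM.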

Compound 4, inhibition constant: 35 nM
Beside the measured number, compound 4's estimate is 1.3-fold (0.11 log units) above it, and the stated range covers the measured number.
By their numbers in this assay, from the lowest: compounds 1, 4 and 2 (each within the scatter of the next); then compound 3.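

Set against the earlier compounds, this result adds a first look at unsaturation in the chain: in this assay, the step of a 1.4-fold lower number from compound 2 to compound 4 (0.15 log units; within the scatter) shows that a double bond can be added at this position, on a saturated chain carbon bound to a double-bonded nitrogen, without a change that can be told from the scatter, and the step of a 1.1-fold higher number from compound 1 to compound 4 (0.03 log units; within the scatter) for vinyl in place of methyl reads the same way. The larger gap stays tied to the whole group on the oxygen, since the step of a 6.0-fold lower number from compound 3 to compound 4 (0.78 log units; beyond the scatter) lies beyond the scatter and is of modest size, so compound 4 sits with compound 1 and compound 2 and apart from compound 3. Nothing measured here accounts for these numbers.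

The group of compound 3 differs from the others in both its oxygen and its three-membered carbon ring, so the shown compounds cannot separate the contribution of each of these two features. As far as these compounds go, how far this tolerance extends also remains open for a longer chain such as butyl, for a benzyl group, or for a chain ending in an amine.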